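From 2-nitrophenyl to 3-bromophenyl on a shared core

The source may report more compounds than this note shows. Statements on the series, on what has been measured and on what is new or still open speak of the compounds shown alone.

In a functional assay on NRK-49F cells (Rattus norvegicus) for cytotoxicity, read by MTT assay, with a stated time of 24 h (a lower number here means a stronger inhibitor, a higher number a weaker inhibitor), compound 1 (`COc1ccc(/C=C(\C#N)C(=O)N/N=C(\C)c2c(O)c3ccc(O)cc3oc2=O)cc1OC`) gives 45300 nM and compound 2 (`C/C(=N\NC(=O)/C(C#N)=C/c1ccccc1[N+](=O)[O-])c1c(O)c2ccc(O)cc2oc1=O`) gives 68600 nM. These two values lie within the scatter of each other, so the numbers shown do not separate compound 2 from compound 1.

Compound 3 (`C/C(=N\NC(=O)/C(C#N)=C/c1cccc(Br)c1)c1c(O)c2ccc(O)cc2oc1=O`) carries 3-bromophenyl in place of 2-nitrophenyl on a double-bonded chain carbon bound to a double-bonded chain carbon. For the measured compounds named here, only one measured step bears on this place. It is a 1.5-fold higher number from compound 1 to compound 2 (0.18 log units; within the scatter), where 2-nitrophenyl took the place of 3,4-dimethoxyphenyl, and it stayed within the scatter. Going by the values given here, no measured compound carries bromine, so the data offer no direct reading of that group. Among the compounds with values here, with this single small step as the only guide, no change beyond the scatter is expected in this assay. The expected step is a 1.2-fold lower number from compound 2 to compound 3 (0.10 log units; within the scatter). For compound 3 the estimated value is 55000 nM, with an expected range of 20000 nM to 130000 nM.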

Compound 3, half-maximal inhibitory concentration: 59400 nM
Compound 3: middle estimate off by 1.1-fold (0.03 log units), on the low side; the measured number falls inside the stated range.
By their numbers in this assay, from the lowest: compounds 1, 3 and 2 (each within the scatter of the next).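

In this assay the change from 2-nitrophenyl to 3-bromophenyl gives a 1.2-fold lower number from compound 2 to compound 3 (0.06 log units; within the scatter) and the change from 3,4-dimethoxyphenyl to 3-bromophenyl gives a 1.3-fold higher number from compound 1 to compound 3 (0.12 log units; within the scatter) at the same place, on a double-bonded chain carbon bound to a double-bonded chain carbon. All three pairs among these compounds now lie within the scatter, so a third group, this time bearing bromine and counting no hydrogen-bond acceptors, does not separate itself from the two groups that carry them. Nothing at hand accounts for why these three groups read alike.

Every compound shown keeps a substituted phenyl ring at this place, so what an amine or a carboxylic acid on that ring, or a longer alkyl chain in place of the ring, would do in this assay stays open. No step shown reaches beyond the scatter, which leaves unsettled whether any change at this place can move the number at all, and the shared core stays the same throughout.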